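A few compounds are considered here, and "the series" means these few. Any claim that something is new, unique, unknown or untested is made for them only; others in the source may bear on it.

In an ADME assay on the whole organism (plasma) for pharmacokinetics, with Rattus norvegicus as the target, at a dose of 5 mg/kg by the oral route (on this read-out higher numbers stand for higher exposure at the dose given and lower numbers for lower exposure), two compounds have been measured so far. Compound 1 `O=C(NOC[C@H](O)CO)c1ccc2cnsc2c1Nc1ccc(I)cc1F` gives 2870 ng.h/mL, and compound 2 `O=C(NOCCO)c1ccc2[nH]ncc2c1Nc1ccc(I)cc1F` gives 484 ng.h/mL, the lower of the two numbers by a margin beyond the usual scatter. These two compounds differ in more than one place, so their gap does not isolate any single change. Compound 3 `O=C(NOCCO)c1ccc2[nH]ncc2c1Nc1ccc(Br)cc1F` departs from compound 2 at one spot only: bromo in place of iodo on an aromatic carbon, para to a large group. Among the compounds with values here, no measured pair shows this exchange, so the expectation rests on compound 2 at 484 ng.h/mL and on the change being a single halogen swap, and no step beyond the scatter is expected. The estimated step is a 1.1-fold higher number from compound 2 to compound 3 (0.06 log units; within the scatter). For compound 3 the expected value is 550 ng.h/mL, with an estimated range from 200 ng.h/mL to 1500 ng.h/mL.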

Compound 3, area under the concentration-time curve: 528 ng.h/mL
Beside the measured number, compound 3's estimate is 1.0-fold (0.02 log units) above it; measured number inside the range.
By their numbers in this assay, from the lowest: compounds 2 and 3 (each within the scatter of the next); then compound 1.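

In this assay, within the data shown here, the change from 2-fluoro-4-iodophenyl to 4-bromo-2-fluorophenyl gives a 1.1-fold higher number from compound 2 to compound 3 (0.04 log units; within the scatter) and is the only comparison here that isolates one place, since compound 1 and compound 2 differ in more than one. On this aromatic carbon, para to a large group, bromo and iodo therefore read alike in this pair, so this exchange leaves oral exposure in the rat unmoved on this core. No measurement at hand bears on why the two halogens read alike.

As far as these compounds go, it remains open whether chloro, methyl or a nitrile on this carbon would read the same, and whether bromo and iodo would also read alike on the core of compound 1. Whether the gap between compound 1 and the other two compounds comes from the core or from the side chain cannot be read from these compounds.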